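This account rests on a few compounds, and the source may have more. Where it says the series, first, only, none or still open, it means among the compounds named here.

In an assay on small intestine for displacement of a labelled ligand from acyl-CoA:cholesterol acyltransferase (Oryctolagus cuniculus) (on this read-out lower numbers stand for stronger inhibition and higher numbers for weaker inhibition), compound 3 `CSc1cc(C)nc(SC)c1NC(=O)N(Cc1ccc(F)cc1)Cc1cccc(-c2cc[nH]n2)c1` gives 250 nM, the highest number among the three measured compounds. Compound 1 `CSc1cc(C)nc(SC)c1NC(=O)N(Cc1ccccc1)Cc1cccc(-c2cc[nH]n2)c1` gives 99 nM, and compound 2 `CSc1cc(C)nc(SC)c1NC(=O)N(Cc1ccc(N(C)C)cc1)Cc1cccc(-c2cc[nH]n2)c1` gives 72 nM. Compound 4 `COc1ccc(CN(Cc2cccc(-c3cc[nH]n3)c2)C(=O)Nc2c(SC)cc(C)nc2SC)cc1` differs from compound 3 by methoxy in place of fluoro on an aromatic carbon. The measured steps that bear on this change are those at that aromatic carbon: a 2.5-fold higher number from compound 1 to compound 3 (0.40 log units; beyond the scatter) and a 3.5-fold higher number from compound 2 to compound 3 (0.54 log units; beyond the scatter), both modest and both beyond the scatter, which means that in the two cases seen, replacing fluoro by another group went with a lower number. Methoxy itself is untested there, and the step expected for compound 4 is a 2.3-fold lower number from compound 3 to compound 4 (0.36 log units; beyond the scatter), a modest decrease. Compound 4 is accordingly estimated at 110 nM, within a range from 50 nM to 250 nM.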

Compound 4, half-maximal inhibitory concentration: 200 nM
Beside the measured number, compound 4's estimate is 1.8-fold (0.26 log units) below it; the measured number falls inside the stated range.
By their numbers in this assay, from the lowest: compounds 2 and 1 (each within the scatter of the next); then compounds 4 and 3 (each within the scatter of the next).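

In this assay, replacing fluoro on this aromatic carbon no longer always goes with a clear drop, since the change to methoxy gives a 1.3-fold lower number from compound 3 to compound 4 (0.10 log units; within the scatter) and stays level with fluoro. Methoxy instead stands apart from hydrogen, with a 2.0-fold higher number from compound 1 to compound 4 (0.31 log units; beyond the scatter) and from dimethylamino, with a 2.8-fold higher number from compound 2 to compound 4 (0.44 log units; beyond the scatter) as well, so the four compounds form two groups, compound 1 with compound 2 and compound 3 with compound 4. Nothing available explains this split.

From the compounds shown here alone, it remains open whether an ethoxy group, a primary amine or a carboxylic acid at this position would fall with compound 1 and compound 2 or with compound 3 and compound 4.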